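This account rests on a few compounds, and the source may have more. Where it says the series, first, only, none or still open, it means among the compounds named here.

Measured compounds:
compound 1, `COc1ccc(OC)c(-c2cc(-c3ccccc3)nn2-c2ccc(S(N)(=O)=O)cc2)c1`, 40700 nM
compound 2, `Oc1ccc(O)c(-c2cc(-c3ccccc3)nn2-c2ccccc2)c1`, 63700 nM
compound 3, `Oc1ccc(O)c(-c2cc(-c3ccc(Cl)cc3)nn2-c2ccccc2)c1`, 33200 nM

All three numbers come from a functional assay on cells (Cancer cell lines, Homo sapiens) for cytotoxicity, read by sulforhodamine B assay, with a stated time of 48 h; on this read-out higher numbers stand for weaker inhibition of growth and lower numbers for stronger inhibition of growth. Compound 2 gives the highest of the three numbers, but its gaps to compound 1 and to compound 3 are both within the scatter, so no order among the three can be read from them.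

Compound 4, `NS(=O)(=O)c1ccc(-n2nc(-c3ccccc3)cc2-c2cc(O)ccc2O)cc1`, has not been measured. It differs from compound 2 in one place: sulfamoyl in place of hydrogen on an aromatic carbon. Among the measured compounds shown here, the only measured single step is a 1.9-fold lower number from compound 2 to compound 3 (0.28 log units; within the scatter), and that step concerns a chloro group on a different ring, so it does not bear directly on the sulfamoyl change. For the measured compounds named here, compound 1 also carries a sulfamoyl group, but it differs from compound 2 in more than one place, so its value shows only that a sulfamoyl-bearing compound sits in the same range as the others.

Going by the values given here, with no direct precedent, no step beyond the scatter is expected in this assay. For compound 4 the estimate is 45000 nM, with a range from 18000 nM to 110000 nM, which is the expected step of a 1.4-fold lower number from compound 2 to compound 4 (0.15 log units; within the scatter).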

Compound 4, concentration for total growth inhibition: 100000 nM
Compound 4: middle estimate off by 2.2-fold (0.35 log units), on the low side; the measured number falls inside the stated range.
By their numbers in this assay, from the lowest: compounds 3, 1, 2 and 4 (each within the scatter of the next, the first and the last beyond it).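

In this assay, sulfamoyl on the aromatic carbon para to a large group gives a 1.6-fold higher number from compound 2 to compound 4 (0.20 log units; within the scatter), so this single change on the dihydroxy compound has no readable effect on growth inhibition. Among the compounds shown here, with sulfamoyl held in place, 2,5-dihydroxyphenyl in place of 2,5-dimethoxyphenyl gives a 2.5-fold higher number from compound 1 to compound 4 (0.39 log units; beyond the scatter), a modest step and the only single-place step that lies beyond the scatter, which makes this exchange, not the sulfamoyl change, the one with a readable effect so far. Nothing available here accounts for either step.

As far as these compounds go, whether an amine or a carboxylic acid at the sulfamoyl position would move the number beyond the scatter remains open. So does whether the dimethoxy-to-dihydroxy step holds on a compound with hydrogen at that position.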